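This account rests on a few compounds, and the source may have more. Where it says the series, first, only, none or still open, it means among the compounds named here.

Compound 1 `CCCCC/C=C\C/C=C\CCCCCCCc1cc(=O)c2c(O)c(C)c(OCOC)c(C)c2o1`: 16100 nM
Compound 2 `CCCC/C=C\CCCCCCCCCc1cc(=O)c2c(O)cc(OCOC)c(C)c2o1`: > 87000 nM

Both compounds were tested in a functional assay on MDA-MB-231 cells (Homo sapiens) for antiproliferative activity, read by MTT assay; on this read-out lower numbers stand for stronger inhibition and higher numbers for weaker inhibition. Compound 1 gives a true number, 16100 nM. Compound 2 stands at a limit of the assay and not at a number, > 87000 nM.

Compound 3 `CCCCC/C=C\C/C=C\CCCCCCCc1cc(=O)c2c(O)cc(OCOC)c(C)c2o1` keeps the core of compound 2 and alters only the chain: deca-1,4-dien-1-yl in place of oct-3-en-1-yl on a saturated chain carbon, seven bonds along the chain from an aromatic carbon. In words, deca-1,4-dien-1-yl takes the place of oct-3-en-1-yl, on a saturated chain carbon, seven bonds along the chain from an aromatic carbon.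

Among the compounds with values here, no measured pair shows this change alone, so the forecast is loose. Compound 1 at 16100 nM shows that a measurable number is possible among these compounds, so a modest move towards stronger inhibition seems more likely than none. The estimated change is an at least 1.4-fold lower number from compound 2 to compound 3 (0.16 log units; that floor lies within the scatter). For compound 3 the expected value is 60000 nM, within an estimated range of 20000 nM to 150000 nM.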

Compound 3, half-maximal inhibitory concentration: 16100 nM
For compound 3 the middle estimate is 3.7-fold (0.57 log units) above the measured one, and the stated range ends above it.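

Swapping oct-3-en-1-yl for deca-1,4-dien-1-yl on a saturated chain carbon, seven bonds along the chain from an aromatic carbon, gives an at least 5.4-fold lower number from compound 2 to compound 3 (0.73 log units; beyond the scatter) in this assay and so shows that the chain alone can bring a measurable number on this core. Compound 2 sits at a limit and not at a number, so that step gives only a smallest size: the limit of > 87000 nM in this assay, at which 1 of the 3 values shown sits. With the deca-1,4-dien-1-yl chain in place, hydrogen in place of methyl on an aromatic carbon gives no change at the digits printed from compound 1 to compound 3 (within the scatter) and so leaves the number as it was.

The extra carbons and the added double bond arrive together in the chain swap, and the compounds shown do not separate them. Also open, as far as these compounds go, is what a longer chain with no double bond, or a chain carrying an amine, would do here.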